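The compounds below may be only part of what the source reports. "The series", "measured", "known", "first", "only" and "open" are said of these compounds alone.

Compound 1 `N#CC1=C(N)Oc2c(c3nc4ccccc4nc3c3ccccc23)C12C(=O)N(Cc1cnnn1-c1ccc(Cl)cc1)c1ccccc12`: in a functional assay on MCF7 cells (Homo sapiens) for antiproliferative activity, read by MTT assay, with a stated time of 48 h (a lower number here means a stronger inhibitor, a higher number a weaker inhibitor), compound 1 gives > 50000 nM, a limit of the assay.
Compound 2 `N#CC1=C(N)Oc2c(c3nc4ccccc4nc3c3ccccc23)C12C(=O)N(Cc1cnnn1-c1ccccc1Cl)c1ccccc12`: in this assay compound 2 gives > 50000 nM, likewise a limit.
Compound 3 `N#CC1=C(N)Oc2c(c3nc4ccccc4nc3c3ccccc23)C12C(=O)N(Cc1cnnn1-c1cccc(Cl)c1)c1ccccc12`: in this assay compound 3 gives 43600 nM.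

Among the measured compounds shown here, compound 3 holds the only number; the other two values are limits, as the limit of > 50000 nM in this assay, at which 2 of the 3 values shown sit, records. The measured steps are small or unreadable: an at least 1.1-fold lower number from compound 1 to compound 3 (0.05 log units; that floor lies within the scatter) and an at least 1.1-fold lower number from compound 2 to compound 3 (0.05 log units; that floor lies within the scatter) both sit within the scatter, and a step that the two limits leave unreadable from compound 1 to compound 2 cannot be sized between two limits. Compound 4 `N#CC1=C(N)Oc2c(c3nc4ccccc4nc3c3ccccc23)C12C(=O)N(Cc1cnnn1-c1ccccc1Br)c1ccccc12` differs from compound 3 by 2-bromophenyl in place of 3-chlorophenyl on an aromatic nitrogen, placing a 2-halophenyl on the triazole nitrogen as in compound 2. Since compound 2 gives > 50000 nM, a limit, no step beyond the scatter is expected in this assay, and a limit is again the likely outcome. Compound 4 is estimated at 60000 nM, range 30000 nM to 150000 nM, an expected step of a 1.4-fold higher number from compound 3 to compound 4 (0.14 log units; within the scatter).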

Compound 4, half-maximal inhibitory concentration: > 50000 nM
Compound 4 was reported as a limit; the forecaster's own chance of this, stated with the estimate: 60%; the middle value is on the limit's open side.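

Bromo in place of chloro on the 2-halophenyl gives no readable number in this assay: compound 4 is a limit, as compound 2 is. Among the compounds shown here, the only readable new step is an at least 1.1-fold higher number from compound 3 to compound 4 (0.05 log units; that floor lies within the scatter), and the steps joining compound 4 to compound 1 and compound 2 cannot be read. Four halophenyl compounds now show one halogen swap and three chloro placements, and most values gather at a single point: the limit of > 50000 nM in this assay, at which 3 of the 4 values shown sit.

Going by these compounds, what an amine or a carboxylic acid on this phenyl ring would give in this assay stays open. Also open, on these data alone, is whether any change at this nitrogen moves a value beyond the scatter.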